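A Second Fluoro Group on the Shared Core

The source may report more compounds than this note shows. Statements on the series, on what has been measured and on what is new or still open speak of the compounds shown alone.

In a functional assay (aorta) with Rattus norvegicus as the target (a higher number here means that more compound is needed for the effect, a lower number that less compound is needed), compound 1 (`C/N=C(/S)C1=CC(C)(C)Oc2ccc([N+](=O)[O-])cc21`) gives 1.35 nM as its reading. Compound 2 (`C/N=C(/S)C1=CC(C)(CF)Oc2ccc([N+](=O)[O-])cc21`) stands at 1.62 nM and so lies within the scatter of compound 1, with no real separation between the two.

Compound 3 (`C/N=C(/S)C1=CC(CF)(CF)Oc2ccc([N+](=O)[O-])cc21`) has not yet been measured. It differs from compound 2 by one further replacement (fluoro in place of hydrogen on a saturated chain carbon bound to a saturated ring carbon), which, cut one bond further out, reads methyl to fluoromethyl.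

Within the data shown here, one measured step bears on this change. Among the measured compounds shown here, the same replacement of hydrogen by fluoro gave a 1.2-fold higher number from compound 1 to compound 2 (0.08 log units; within the scatter) and is the only guide available. The data do not show whether a second replacement behaves like the first. With that single small step as precedent, no shift beyond the scatter is expected in this assay, and no firm direction can be claimed, though a slight drift towards a higher number would match the earlier step. The estimated change is a 1.2-fold higher number from compound 2 to compound 3 (0.07 log units; within the scatter) on this reasoning. Compound 3 is expected at about 1.9 nM in an estimated range from 0.8 nM to 4.5 nM for its reading.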

Compound 3, half-maximal effective concentration: 0.479 nM
Compound 3: the middle estimate sits 4.0-fold (0.60 log units) above what was measured, and the stated range ends above it.
By their numbers in this assay, from the lowest: compound 3; then compounds 1 and 2 (each within the scatter of the next).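

In this assay, the replacement of hydrogen by fluoro on a saturated chain carbon bound to a saturated ring carbon now gives a step beyond the scatter, a 3.4-fold lower number from compound 2 to compound 3 (0.53 log units; beyond the scatter), whereas the same replacement earlier gave only a 1.2-fold higher number from compound 1 to compound 2 (0.08 log units; within the scatter). The change therefore has no fixed size on the shared core: methyl to fluoromethyl separated two compounds only in the step starting from compound 2, which already carries a fluoromethyl group, so what the change does here appears to depend on whether that group is present, though this rests on just these two steps. Nothing available explains why the two steps differ.

The compounds shown leave open whether a difluoromethyl or trifluoromethyl group, or a longer chain such as ethyl, at this place would extend the lower number seen for compound 3 or lose it. They also leave open whether a chloromethyl or hydroxymethyl group paired with fluoromethyl would give a similar step, or whether the step is specific to a pair of fluoromethyl groups.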